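The compounds below may be only part of what the source reports. "The series", "measured", "known", "first", "only" and "open" are said of these compounds alone.

Measured in an ADME assay on CRFK cells (Felis catus) for cytotoxicity; a higher number here means that more compound is tolerated, a lower number that less compound is tolerated:
- compound 1 `CCN(CC)CN1C(=O)/C(=N/NC(N)=S)c2cc(Cl)ccc21`: > 100000 nM (a limit)
- compound 2 `CCN(CC)CN1C(=O)/C(=N/NC(=S)Nc2ccc(OC)cc2)c2ccccc21`: 3500 nM

Among the compounds with values here, compound 2 holds the only actual number, 3500 nM. Compound 1 sits at a limit of this assay, > 100000 nM, and this is not a number.

The next compound to be measured is compound 3 `CCN(CC)CN1C(=O)/C(=N/NC(=S)Nc2ccc(C)cc2)c2ccccc21`. It carries methyl in place of methoxy on an aromatic carbon, para to a large group, on the same core as compound 2: methyl in place of methoxy on an aromatic carbon.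

Within the data shown here, no measured pair shows this change, so the expectation rests on compound 2 at 3500 nM. The expected change is small, a 1.1-fold higher number from compound 2 to compound 3 (0.06 log units; within the scatter), and no shift beyond the usual scatter is anticipated in either direction. For compound 3 the estimated value in this assay is 4000 nM, with an expected range of 1300 nM to 12000 nM.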

Compound 3, half-maximal cytotoxic concentration: 3800 nM
Compound 3: the middle estimate sits 1.1-fold (0.02 log units) above what was measured; low and high end bracket the measured number.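

Methyl in place of methoxy on an aromatic carbon, para to a large group, is the first one-place change that can be read in this assay, and it gives a 1.1-fold higher number from compound 2 to compound 3 (0.04 log units; within the scatter), so compound 2 and compound 3 cannot be told apart here. The 4-methoxyphenyl and 4-methylphenyl groups are therefore interchangeable at this position in this assay, though this rests on a single pair and extends no further. Nothing available bears on why this step is as it is.

From the compounds shown here alone, it remains open whether an amine or a carboxylic acid at this position would separate from compound 2 in this assay. A longer chain such as ethoxy in the same place, or a phenyl ring with no group there at all, is equally unaddressed.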